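A few compounds are considered here, and "the series" means these few. Any claim that something is new, unique, unknown or untested is made for them only; others in the source may bear on it.

Measured so far:
- Compound 1, `CCCCOc1nc(N)nc2[nH]cnc12`: 493000 nM
- Compound 2, `C#CCOc1nc(N)nc2[nH]cnc12`: 20000 nM

In an assay on HT-29 cells for inhibition of Methylated-DNA--protein-cysteine methyltransferase (Homo sapiens) (a lower number here means a stronger inhibitor, a higher number a weaker inhibitor), compound 1 gives 493000 nM and compound 2 gives 20000 nM. For the measured compounds named here, the one step measured is a 25-fold lower number from compound 1 to compound 2 (1.39 log units; beyond the scatter), so compound 2 stands with the lowest of the two numbers, its only neighbour being compound 1 with the higher one.

Compound 3, `Nc1nc(OCC2=CCCC2)c2nc[nH]c2n1`, has not yet been measured. It differs from compound 2 in one place: cyclopent-1-en-1-yl in place of ethynyl on a saturated chain carbon bound to an oxygen on an aromatic ring. Going by the values given here, the only step that bears on this change is a 25-fold lower number from compound 1 to compound 2 (1.39 log units; beyond the scatter), which shows how strongly the group on that chain carbon can move the number. That step compared a saturated chain with a triple-bonded one; the cyclopent-1-en-1-yl group brings a double bond outside aromatic rings and a ring, so the comparison is indirect. A moderate change is expected, a 5.0-fold lower number from compound 2 to compound 3 (0.70 log units; beyond the scatter), with the number for compound 3 estimated at 4000 nM, in the range 800 nM to 25000 nM.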

Compound 3, half-maximal inhibitory concentration: 390 nM
Compound 3: middle estimate off by 10-fold (1.01 log units), on the high side; the measured number lies below the stated range.
By their numbers in this assay, from the lowest: compound 3; then compound 2; then compound 1.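

In this assay, the group on a saturated chain carbon bound to an oxygen on an aromatic ring can move the number much further than the first pair revealed: cyclopent-1-en-1-yl gives a 51-fold lower number from compound 2 to compound 3 (1.71 log units; beyond the scatter) and a 1300-fold lower number from compound 1 to compound 3 (3.10 log units; beyond the scatter) against the two earlier groups. A five-membered non-aromatic ring of carbon only, with one double bond outside aromatic rings, thus puts compound 3 lowest of the three, ahead of both the triple-bonded and the saturated chain. No evidence at hand accounts for this gain.

The three compounds cannot separate the share of the ring from that of the double bond, which a saturated cyclopentyl group on that carbon would address. They also leave open whether a larger ring, such as cyclohexenyl or phenyl, would lower the number further.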